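Bromo-indolinone series: dimethylamino for chloro on the pendant ring

The source may hold more compounds than are shown below. What is called first, only, known or untested is meant among the compounds shown, and "the series" means these compounds.

Compound 1 `O=C1N=C(N2N=C(c3ccc(Cl)cc3)CC2c2ccc(Cl)cc2)S/C1=C1\C(=O)Nc2ccccc21` gives 68200 nM in a functional assay on Mino cells (Homo sapiens) for cytotoxicity, read by MTT assay, with a stated time of 72 h (a lower number here means a stronger inhibitor, a higher number a weaker inhibitor), and compound 2 `O=C1N=C(N2N=C(c3ccc(Cl)cc3)CC2c2ccc(Cl)cc2)S/C1=C1\C(=O)Nc2ccc(Br)cc21` gives 730 nM; the step of a 93-fold lower number from compound 1 to compound 2 (1.97 log units; beyond the scatter) is the only one so far, and compound 2 stands lowest of the two numbers. Compound 3 `CN(C)c1ccc(C2CC(c3ccc(Cl)cc3)=NN2C2=NC(=O)/C(=C3/C(=O)Nc4ccc(Br)cc43)S2)cc1` differs from compound 2 by dimethylamino in place of chloro on an aromatic carbon. Among the compounds with values here, no measured step touches this ring, so the bromo step gives no guide, and the expectation is a change of no more than the scatter, in either direction. Compound 3 is therefore estimated at 1000 nM (range 250 nM to 4000 nM), a step of a 1.4-fold higher number from compound 2 to compound 3 (0.14 log units; within the scatter).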

Compound 3, half-maximal inhibitory concentration: 160 nM
Compound 3: the middle estimate sits 6.3-fold (0.80 log units) above what was measured; the measured number lies below the stated range.
By their numbers in this assay, from the lowest: compound 3; then compound 2; then compound 1.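

Exchanging 4-chlorophenyl for 4-(dimethylamino)phenyl gives a 4.6-fold lower number from compound 2 to compound 3 (0.66 log units; beyond the scatter) in this assay. Within the data shown here, this is the first measured change on the pendant ring, and it shows that the chloro group can be replaced here without loss, with a modest gain on top of the bromo step. Nothing on hand accounts for the gain.

Still open, from the compounds shown here alone, is whether a primary amine, a morpholine or a carboxylic acid at this position would go further. Also open, going by these compounds, is whether dimethylamino gives a similar step with hydrogen in place of bromo.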